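Hydroxy to fluoro on the aryl of the quinuclidine-triazole series

The source may report more compounds than this note shows. Statements on the series, on what has been measured and on what is new or still open speak of the compounds shown alone.

Measured so far:
compound 1 `Fc1ccc(-c2cn(C3CN4CCC3CC4)nn2)cc1` — 449 nM
compound 2 `Fc1ccc(-c2cn([C@@H]3CN4CCC3CC4)nn2)cc1` — 515 nM
compound 3 `Oc1ccc(-c2cn([C@H]3CN4CCC3CC4)nn2)cc1` — 7390 nM

In an assay on HEK293 cells for displacement of a labelled ligand from Neuronal acetylcholine receptor; alpha4/beta2 (Homo sapiens), read by scintillation counting, with a stated time of 120 min (a higher number here means a weaker inhibitor, a lower number a stronger inhibitor), compound 3 stands highest of the three numbers; compound 2 lies nearest, compound 1 furthest, both beyond the scatter. Going by the values given here, the step of a 1.1-fold higher number from compound 1 to compound 2 (0.06 log units; within the scatter) is the only one measured between neighbours, and it stays within the scatter; the two differ only in that one is drawn with a defined configuration at the saturated ring carbon and the other without (the fact that one of compounds 1 and 2 is drawn with a defined configuration and the other without, at the place where they differ).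

Compound 4 `Fc1ccc(-c2cn([C@H]3CN4CCC3CC4)nn2)cc1` is not yet measured. From compound 3 the change is fluoro in place of hydroxy on an aromatic carbon. Among the compounds with values here, no measured step covers a hydroxy-to-fluoro exchange, so nothing sets its size directly. Within the data shown here, what the numbers do show is that the two fluoro compounds, compound 1 and compound 2, both sit far below compound 3 in this assay, whereas compound 3 is the only hydroxy compound. The expectation is therefore a large step downward, a 16-fold lower number from compound 3 to compound 4 (1.22 log units; beyond the scatter), bringing compound 4 close to where compound 1 and compound 2 sit. Compound 4 is estimated at 450 nM, with a range of 150 nM to 1400 nM.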

Compound 4, inhibition constant: 10400 nM
The estimate for compound 4 lay 23-fold (1.36 log units) below the measured number; measured number outside the range, above it.
By their numbers in this assay, from the lowest: compounds 1 and 2 (each within the scatter of the next); then compounds 3 and 4 (each within the scatter of the next).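

In this assay, fluoro in place of hydroxy on an aromatic carbon, para to a large group, gives values that cannot be told apart (a 1.4-fold higher number from compound 3 to compound 4 (0.15 log units; within the scatter)), so this exchange does not separate the two compounds at this position. The large steps instead go with the saturated ring carbon, drawn S in compound 2 and R in compound 4 (a 20-fold higher number from compound 2 to compound 4 (1.31 log units; beyond the scatter)), as the structures show: the fact that one of compounds 2 and 4 is drawn with a defined configuration and the other without, at the place where they differ. The same holds with that carbon drawn without a configuration in compound 1 (a 23-fold higher number from compound 1 to compound 4 (1.36 log units; beyond the scatter)): the fact that one of compounds 1 and 4 is drawn with a defined configuration and the other without, at the place where they differ.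

The compounds shown leave open whether hydroxy and fluoro would also give matching values with the ring carbon drawn S. They also leave open how an amine or a methoxy group would read at the same aromatic carbon.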